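Adding an amino group to compound 2

The source may hold more compounds than are shown below. What is called first, only, known or untested is meant among the compounds shown, and "the series" means these compounds.

The series has two measured members sharing one core. In an ADME assay on L6 cells (Rattus norvegicus) for cytotoxicity (a lower number here means a stronger inhibitor, a higher number a weaker inhibitor), compound 1 `C[C@H]1O[C@@H](n2cnc3c(N)nc(Cl)nc32)[C@H](O)[C@@H]1O` gives 147000 nM and compound 2 `C[C@H]1O[C@@H](n2cnc3c(N)nc(N)nc32)[C@H](O)[C@@H]1O` gives 338000 nM, the higher of the two numbers. Next comes compound 3 `C[C@H]1O[C@@H](n2cnc3c(N)nc(NN)nc32)[C@H](O)[C@@H]1O`, which differs from compound 2 by amino in place of hydrogen on a nitrogen on an aromatic ring.

Within the data shown here, only one measured step bears on this change: a 2.3-fold higher number from compound 1 to compound 2 (0.36 log units; beyond the scatter), a modest step with amino in place of chloro on an aromatic carbon. Among the measured compounds shown here, it involves a different replacement, and no measured step shows what amino on that nitrogen does in this assay. The direction is therefore uncertain, and a step no larger than that modest one is expected. The expected change is small, a 1.7-fold lower number from compound 2 to compound 3 (0.23 log units; within the scatter). For compound 3 the estimated value is 200000 nM, with an expected range from 70000 nM to 400000 nM.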

Compound 3, half-maximal inhibitory concentration: 188000 nM
Estimate against measurement, compound 3: 1.1-fold (0.03 log units) above; measured number inside the range.
By their numbers in this assay, from the lowest: compounds 1, 3 and 2 (each within the scatter of the next, the first and the last beyond it).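

In this assay, among these compounds, the first reading of amino in place of hydrogen on a nitrogen on an aromatic ring is a 1.8-fold lower number from compound 2 to compound 3 (0.25 log units; within the scatter) and does not separate aminoamino from amino at this position. Aminoamino in place of chloro on an aromatic carbon reads as a 1.3-fold higher number from compound 1 to compound 3 (0.11 log units; within the scatter) and so does not separate it from chloro either, although a 2.3-fold higher number from compound 1 to compound 2 (0.36 log units; beyond the scatter) does separate amino from chloro. None of the data shown bears on the cause of these results.

Open, from the compounds shown here alone, is whether a larger group on that nitrogen, such as a methyl, an acetyl or a longer alkyl chain, would give a step beyond the scatter. Also open, going by these compounds, is whether a hydroxyl or a methoxy group in place of the aminoamino would read apart from compound 3.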